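The compounds below may be only part of what the source reports. "The series", "measured", "known", "first", "only" and "open" are said of these compounds alone.

Of the compounds shown here, two built on a shared core have been tested in an ADME assay on Vero cells (Chlorocebus sabaeus) for cytotoxicity; on this read-out lower numbers stand for stronger inhibition and higher numbers for weaker inhibition. Compound 1 `CC(C)(C)N1C(=O)c2cccnc2C1=O` gives 33000 nM, and compound 2 `Cc1cccc(C)c1N1C(=O)c2nccnc2C1=O` gives 18000 nM; these two numbers sit within the scatter of each other, so compound 1 does not stand apart from its companion. Compound 3 `CCN1C(=O)c2cccnc2C1=O` still awaits measurement in this assay. It differs from compound 1 by ethyl in place of tert-butyl on an amide-type nitrogen in a ring. Without any step between measured compounds to draw on, the expected change a 1.1-fold higher number from compound 1 to compound 3 (0.03 log units; within the scatter) is none beyond the scatter. Compound 3 is accordingly estimated at 35000 nM, with a range from 15000 nM to 80000 nM.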

Compound 3, half-maximal inhibitory concentration: > 100000 nM
Compound 3 was reported as a limit; the forecaster's own chance of this, stated with the estimate: 25%; middle value at least 2.8-fold (0.45 log units) away from the limit.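

In this assay, the group on the amide-type nitrogen in a ring does affect the read-out: ethyl in place of tert-butyl gives an at least 3.0-fold higher number from compound 1 to compound 3 (0.48 log units; beyond the scatter), the only single-change comparison among these compounds. Of this pair, compound 3 is the weaker inhibitor. Its value is a limit and not a number, so the step has a known minimum but no known full size: the limit of > 100000 nM in this assay, at which 1 of the 3 values shown sits.

Going by these compounds, what a propyl chain, a longer butyl chain or a chain carrying an amine would give on this nitrogen remains open. On these data alone, whether the trend holds beyond this one pair also remains open.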